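The source may hold more compounds than are shown below. What is called first, only, known or untested is meant among the compounds shown, and "the series" means these compounds.

Measured in an ADME assay on MCF7 cells (Homo sapiens) for cytotoxicity, with a stated time of 72 h; a higher number here means a weaker inhibitor, a lower number a stronger inhibitor:
- compound 1 `Oc1cccc(CNc2ncnc3c2ncn3C2CCCCO2)c1`: > 100000 nM (a limit, not a number)
- compound 2 `Oc1ccc(CNc2ncnc3c2ncn3C2CCCCO2)cc1`: > 100000 nM (a limit, not a number)
- compound 3 `COc1cccc(CNc2ncnc3c2ncn3C2CCCCO2)c1`: 97000 nM

Among the compounds with values here, compound 3 carries the only actual number. The other two entries are limits: the limit of > 100000 nM in this assay, at which 2 of the 3 values shown sit.

The next compound is compound 4 `Oc1cccc(CNc2ncnc3c2ncn3C2CCCCO2)c1O`, with 2,3-dihydroxyphenyl in place of 3-methoxyphenyl on a saturated chain carbon bound to a nitrogen on an aromatic ring. Within the data shown here, no measured compound carries 2,3-dihydroxyphenyl, so the evidence is indirect.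

The nearest measured steps are those linking compound 3 to the hydroxy compounds: an at least 1.0-fold lower number from compound 1 to compound 3 (0.01 log units; that floor lies within the scatter) and an at least 1.0-fold lower number from compound 2 to compound 3 (0.01 log units; that floor lies within the scatter). Both are floors only and leave the true sizes open. The step between the two hydroxy compounds gives no further help: a step that the two limits leave unreadable from compound 1 to compound 2. Read in reverse, the first two steps give no sign that exchanging the methoxy group for hydroxy groups strengthens inhibition in this assay.

No step beyond the scatter is therefore expected, and the estimated step is a 1.0-fold higher number from compound 3 to compound 4 (0.01 log units; within the scatter). The estimate for compound 4 is 100000 nM, with an expected range of 40000 nM to 200000 nM.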

Compound 4, half-maximal inhibitory concentration: > 100000 nM
Compound 4 was reported as a limit; the forecaster's own chance of this, stated with the estimate: 65%; the middle value sits exactly at the limit.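

In this assay, at the place on a saturated chain carbon bound to a nitrogen on an aromatic ring, 2,3-dihydroxyphenyl reads only as a limit, as 3-hydroxyphenyl and 4-hydroxyphenyl do, so adding a second hydroxy to the ring of compound 1 yields no measurable number: the limit of > 100000 nM in this assay, at which 3 of the 4 values shown sit.

Replacing 3-methoxyphenyl with the dihydroxy group gives an at least 1.0-fold higher number from compound 3 to compound 4 (0.01 log units; that floor lies within the scatter), and this floor leaves the true size of the step open. The steps linking compound 4 to compound 1 and to compound 2 cannot be read, with limits at both ends.

Every group shown at this place is a phenyl ring carrying hydroxy or methoxy, and none gives a number clearly clear of the limit, so it remains open whether any group here can strengthen inhibition in this assay. On these data alone, what a chlorine, an amine or a carboxylic acid on that phenyl ring would give also stays open, as does the effect of any change to the shared core.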